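Shortening the selenium chain on a pyridopyrimidine amine

This account rests on a few compounds, and the source may have more. Where it says the series, first, only, none or still open, it means among the compounds named here.

Compound 1 `C[Se]c1nc([Se]C)c2cccnc2n1`: in a functional assay on MCF7 cells (Homo sapiens) for cytotoxicity, read by MTT assay, with a stated time of 72 h (a lower number here means a stronger inhibitor of growth, a higher number a weaker inhibitor of growth), compound 1 gives "not determined" (no result reported)
Compound 2 `Nc1nc([SeH])nc2ncccc12`: compound 2 gives 37300 nM
Compound 3 `CCCCC[Se]c1nc(N)c2cccnc2n1`: compound 3 gives 22700 nM

Compound 3 holds the lowest of the two numbers reported in this assay, and its nearest neighbour is compound 2, with the step of a 1.6-fold lower number from compound 2 to compound 3 (0.22 log units; within the scatter) lying within the scatter. Compound 4 `C[Se]c1nc(N)c2cccnc2n1` differs from compound 3 by hydrogen in place of butyl on a saturated chain carbon bound to a selenium atom. For the measured compounds named here, the only step that bears on this change is the one from compound 2 to compound 3, which altered the same selenium chain and stayed within the scatter. Compound 4 is therefore expected to show no step beyond the scatter, with an estimated change of a 1.2-fold higher number from compound 3 to compound 4 (0.09 log units; within the scatter). Compound 4 is estimated at 28000 nM, in a range from 10000 nM to 75000 nM.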

Compound 4, concentration for 50% growth inhibition: 43000 nM
For compound 4 the middle estimate is 1.5-fold (0.19 log units) below the measured one; low and high end bracket the measured number.
By their numbers in this assay, from the lowest: compounds 3, 2 and 4 (each within the scatter of the next).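

Going from pentyl to methyl on the selenium in this assay gives a 1.9-fold higher number from compound 3 to compound 4 (0.28 log units; within the scatter), so removing butyl from the chain moves the number no further than the scatter. Methyl in place of the hydrogen on the selenium gives a 1.2-fold higher number from compound 2 to compound 4 (0.06 log units; within the scatter), which means that compound 2, compound 3 and compound 4 cannot be told apart across these three substituents. No evidence is available on why this is so.

As far as these compounds go, whether a longer chain than pentyl would leave the number equally unmoved remains open. So does the effect of an amine or a carboxylic acid in place of the pentyl.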